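The compounds below may be only part of what the source reports. "The series", "measured", "known", "first", "only" and "open" are said of these compounds alone.

Compounds measured so far:
- Compound 1, `Cc1nc(S(C)(=O)=O)ccc1Oc1ncnc(OC2CCN(C(=O)OC3CCC3)CC2)c1F`, gives 81% in a functional assay on isolated protein for inhibition of Glucose-dependent insulinotropic receptor (Rattus norvegicus), read by HTRF and cAMP accumulation; a lower number here means a smaller maximal response, a higher number a larger maximal response.
- Compound 2, `Cc1nc(S(C)(=O)=O)ccc1Oc1ncnc(OC2CCN(C(=O)OC(C)(C)C(F)(F)F)CC2)c1F`, gives 79%.
- Compound 3, `Cc1nc(S(C)(=O)=O)ccc1Oc1ncnc(OC2CCN(C(=O)OC(C)(C)CF)CC2)c1F`, gives 95%.

Compound 3 stands highest of the three: its largest response exceeds that of compound 1 by a modest step, a number 14 percentage points higher from compound 1 to compound 3 (beyond the scatter), and that of compound 2 by a slightly larger one, a number 16 percentage points higher from compound 2 to compound 3 (beyond the scatter), both beyond the scatter. Compound 1 and compound 2 sit within the scatter of each other, a number 2 percentage points lower from compound 1 to compound 2 (within the scatter).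

Compound 4, `Cc1nc(S(C)(=O)=O)ccc1Oc1ncnc(OC2CCN(C(=O)O[C@@H](C)C(F)(F)F)CC2)c1F`, has not yet been measured. It differs from compound 3 in one place: 1-(trifluoromethyl)ethyl in place of 1-(fluoromethyl)-1-methylethyl on an oxygen next to a carbonyl group.

Going by the values given here, the step that bears most on this change is the one between compound 2 and compound 3, in which fluoromethyl replaced trifluoromethyl on the same branched group and the response rose by a number 16 percentage points higher from compound 2 to compound 3 (beyond the scatter). Among the compounds with values here, compound 4 reverses that, bringing back trifluoromethyl, though its group carries one methyl fewer than that of compound 2, a difference for which no step is recorded. A modest drop back toward the level of compound 2 is therefore expected, a number 13 percentage points lower from compound 3 to compound 4 (beyond the scatter). Compound 4 is estimated at 82%, within a range from 70% to 94%.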

Compound 4, largest response reached (reported as efficacy), in percent of the reference or control that the assay uses: 80%
For compound 4 the middle estimate is 2 percentage points above the measured one; the measured number falls inside the stated range.
By their numbers in this assay, from the lowest: compounds 2, 4 and 1 (each within the scatter of the next); then compound 3.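

In this assay, 1-(trifluoromethyl)ethyl in place of 1-(fluoromethyl)-1-methylethyl on the oxygen gives a number 15 percentage points lower from compound 3 to compound 4 (beyond the scatter), so the new group does not keep the higher response of compound 3. The trifluoromethyl-bearing groups with and without the extra methyl cannot be told apart, at a number 1 percentage points higher from compound 2 to compound 4 (within the scatter), and the same holds against cyclobutyl, at a number 1 percentage points lower from compound 1 to compound 4 (within the scatter), so among these four only the 1-(fluoromethyl)-1-methylethyl group of compound 3 stands apart. No measurement is at hand that accounts for this pattern.

Going by these compounds, it remains open whether the opposite stereocentre in 1-(trifluoromethyl)ethyl would give a different response. On these data alone, it is also open how a difluoromethyl group or a plain tert-butyl group on the same oxygen would compare with compound 3.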